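Chloro for methyl on the compound 3 scaffold

The compounds below may be only part of what the source reports. "The series", "measured", "known", "first", "only" and "open" are said of these compounds alone.

Measured in a functional assay on PC-3 cells (Homo sapiens) for antiproliferative activity, read by MTT assay, with a stated time of 96 h; a higher number here means a weaker inhibitor of growth, a lower number a stronger inhibitor of growth:
- compound 1 `Clc1ccnc(Nc2ccc3ccccc3n2)c1`: > 30000 nM
- compound 2 `COc1cccc2ccc(Nc3ccccn3)nc12`: 7470 nM
- compound 3 `COc1cccc2ccc(Nc3cc(C)ccn3)nc12`: 3820 nM

The entry for compound 1 is a limit of the assay and not a number. Compound 3, at 3820 nM, has the lowest of the two numerical values in this assay, but it remains within the scatter of compound 2, at 7470 nM.

The next compound is compound 4 `COc1cccc2ccc(Nc3cc(Cl)ccn3)nc12`, which differs from compound 3 by chloro in place of methyl on an aromatic carbon.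

Going by the values given here, one measured step bears on this change, a 2.0-fold lower number from compound 2 to compound 3 (0.29 log units; within the scatter), where methyl takes the place of hydrogen at the same carbon. Among the compounds with values here, that step stays within the scatter, and no measured step shows chloro entering with the rest of the structure unchanged. No shift beyond the scatter is therefore expected, in either direction.

The estimated step is a 1.3-fold lower number from compound 3 to compound 4 (0.10 log units; within the scatter).

For compound 4, the expected value in this assay is 3000 nM, with an estimated range of 1000 nM to 9000 nM.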

Compound 4, concentration for 50% growth inhibition: 11900 nM
Beside the measured number, compound 4's estimate is 4.0-fold (0.60 log units) below it; the measured number lies above the stated range.
By their numbers in this assay, from the lowest: compounds 3, 2 and 4 (each within the scatter of the next, the first and the last beyond it). At a limit, above all of these: compound 1.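

Going by these compounds alone, at this carbon, opposite the ring nitrogen, this assay separates the two substituents: chloro in place of methyl gives a 3.1-fold higher number from compound 3 to compound 4 (0.49 log units; beyond the scatter), the first step here to pass beyond the scatter. Against hydrogen, chloro gives only a 1.6-fold higher number from compound 2 to compound 4 (0.20 log units; within the scatter), so compound 2 remains within the scatter of both compound 3 and compound 4, and the separation appears only between methyl and chloro. With chloro at this carbon, methoxy in place of hydrogen on the core gives an at least 2.5-fold lower number from compound 1 to compound 4 (0.40 log units; beyond the scatter), a step that rests on a limit for compound 1: the limit of > 30000 nM in this assay, at which 1 of the 4 values shown sits.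

Going by these compounds, whether an amine or a carboxylic acid at this carbon would fall with methyl, with chloro or outside both remains open. Within the data shown here, the methoxy step is seen only with chloro present, so its size with methyl or hydrogen at this carbon is also open.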